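From a Methyl to an Isopropyl Side Chain

The source may hold more compounds than are shown below. What is called first, only, known or untested is meant among the compounds shown, and "the series" means these compounds.

Compound 1 `Cc1ncc([N+](=O)[O-])n1CCOC(=O)c1cc(NC(=O)C(C)NC(=O)OCc2ccccc2)ccc1O` and compound 2 `Cc1ncc([N+](=O)[O-])n1CCOC(=O)c1cc(NC(=O)[C@H](C)NC(=O)OCc2ccccc2)ccc1O` share one skeleton. In a functional assay on the whole organism (strain Wistar) for inhibition, with Rattus norvegicus as the target, read by paw edema, with a stated time of 1 h, at a dose of 10 mg/kg by the intraperitoneal route (a higher number here means more inhibition at the dose given (going by the name of the read-out), a lower number less inhibition), compound 1 gives 57.9% and compound 2 gives 58.5%; the step of a number 0.6 percentage points higher from compound 1 to compound 2 (within the scatter) rests only on (the fact that one of compounds 1 and 2 is drawn with a defined configuration and the other without, at the place where they differ). Of the two numbers, compound 2 stands highest, though within the scatter of compound 1. Compound 3 `Cc1ncc([N+](=O)[O-])n1CCOC(=O)c1cc(NC(=O)[C@@H](NC(=O)OCc2ccccc2)C(C)C)ccc1O` carries isopropyl in place of methyl on a saturated chain carbon bound to an amide-type nitrogen and a carbonyl carbon. Among the compounds with values here, no measured step changes this part of the molecule, so the single step offers no guide to its size, and no step beyond the scatter is expected: a number 1.5 percentage points lower from compound 2 to compound 3 (within the scatter). Compound 3 is therefore estimated at 57%, between 44% and 70%.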

Compound 3, a percentage reported as inhibition, in the whole organism at one dose (the size of the read-out at that dose, not a potency): 74.4%
Beside the measured number, compound 3's estimate is 17.4 percentage points below it; the measured number lies above the stated range.
By their numbers in this assay, from the lowest: compounds 1 and 2 (each within the scatter of the next); then compound 3.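

In this assay the side chain on the saturated chain carbon proves able to move the result, with isopropyl in place of methyl giving a number 15.9 percentage points higher from compound 2 to compound 3 (beyond the scatter) and so a change that stands clear of the scatter. Compound 1 and compound 2 could not show this: both carry methyl and differ only in how the configuration is drawn. Nothing shown here explains the gain.

As far as these compounds go, whether a longer chain, a benzyl group or an amine on this carbon would raise inhibition further remains open.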